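The source may report more compounds than this note shows. Statements on the series, on what has been measured and on what is new or still open speak of the compounds shown alone.

Going by the values given here, compound 2 `CCN(CC)CCNC(=O)Nc1nc2ccc(-c3cnc(OC)c(NS(=O)(=O)c4ccc(F)cc4)c3)cc2s1` is one of three compounds measured in a functional assay on A549 cells (Homo sapiens) for antiproliferative activity, read by MTT assay, with a stated time of 72 h; on this read-out higher numbers stand for weaker inhibition and lower numbers for stronger inhibition. In this assay compound 2 gives 450 nM. Compound 1 `COc1ncc(-c2ccc3nc(NC(=O)NCCN4CCCC4)sc3c2)cc1NS(=O)(=O)c1ccc(F)cc1` gives 300 nM in this assay, and compound 3 `COc1ncc(-c2ccc3nc(NC(=O)NC4CC4)sc3c2)cc1NS(=O)(=O)c1ccc(F)cc1` gives 900 nM. Compound 2 therefore sits second highest of the three numbers, and its neighbours are close: the step of a 1.5-fold higher number from compound 1 to compound 2 (0.18 log units; within the scatter) lies within the scatter, and so does the step of a 2.0-fold higher number from compound 2 to compound 3 (0.30 log units; within the scatter).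

Compound 4 `COc1ncc(-c2ccc3nc(NC(=O)NCCN4CCN(C)CC4)sc3c2)cc1NS(=O)(=O)c1ccc(F)cc1` has not yet been measured in this assay. It differs from compound 2 in one place: 4-methylpiperazin-1-yl in place of diethylamino on a saturated chain carbon, two bonds along the chain from an amide-type nitrogen.

The step that bears most directly on this change is the one that exchanged one amine for another at the same place on the chain, a 1.5-fold higher number from compound 1 to compound 2 (0.18 log units; within the scatter), which did not leave the scatter. The two steps that removed the chain entirely, a 3.0-fold higher number from compound 1 to compound 3 (0.48 log units; beyond the scatter) and a 2.0-fold higher number from compound 2 to compound 3 (0.30 log units; within the scatter), were larger and pointed towards weaker inhibition, but compound 4 keeps the chain and its amine. The step from compound 2 to compound 4 is thus expected to stay within the scatter, with no clear direction.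

Compound 4 is estimated to give 400 nM in this assay, with a range from 200 nM to 800 nM, which corresponds to an expected step of a 1.1-fold lower number from compound 2 to compound 4 (0.05 log units; within the scatter).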

Compound 4, half-maximal inhibitory concentration: 550 nM
Estimate against measurement, compound 4: 1.4-fold (0.14 log units) below, and the stated range covers the measured number.
By their numbers in this assay, from the lowest: compounds 1, 2, 4 and 3 (each within the scatter of the next, the first and the last beyond it).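

In this assay, 4-methylpiperazin-1-yl in place of diethylamino on the saturated chain carbon gives a 1.2-fold higher number from compound 2 to compound 4 (0.09 log units; within the scatter), so this larger ring-bearing amine with its second nitrogen is accommodated at this place without leaving the scatter. The exchange for pyrrolidin-1-yl at the same place reads the same way, with a 1.8-fold higher number from compound 1 to compound 4 (0.26 log units; within the scatter), which means that an open-chain amine, a five-membered ring amine and a six-membered ring amine holding a second nitrogen are not told apart by any direct step here. Against cyclopropyl on the amide-type nitrogen, the new compound adds a 1.6-fold lower number from compound 3 to compound 4 (0.21 log units; within the scatter), so compound 4 joins compound 2 in staying within the scatter of compound 3, and the pyrrolidin-1-yl compound remains the only chain-bearing compound with a step beyond it, a 3.0-fold higher number from compound 1 to compound 3 (0.48 log units; beyond the scatter).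

Going by these compounds alone, nothing in the data given explains these numbers or why only that one step leaves the scatter. Going by these compounds, whether a morpholin-4-yl group, a primary amine or a longer chain between the amide-type nitrogen and the amine would stay within this narrow band in this assay remains open.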